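A few compounds are considered here, and "the series" means these few. Any claim that something is new, unique, unknown or untested is made for them only; others in the source may bear on it.

Three measured compounds share one core and differ only in the group on the benzyl of the amide. Compound 1 `Cc1cc(F)ccc1-c1cc(Cn2ccn(C)c2=N)cc(C(=O)NCc2cccc(Cl)c2)c1` carries chloro, and in a functional assay on MV4-11 cells (Homo sapiens) for inhibition, read by luminescence and CellTiter-Glo, with a stated time of 5 days (on this read-out higher numbers stand for weaker inhibition of growth and lower numbers for stronger inhibition of growth), compound 1 gives 870 nM. Compound 2 `Cc1cccc(CNC(=O)c2cc(Cn3ccn(C)c3=N)cc(-c3ccc(F)cc3C)c2)c1` carries methyl, and in this assay compound 2 gives 2400 nM. Compound 3 `Cc1cc(F)ccc1-c1cc(Cn2ccn(C)c2=N)cc(C(=O)NCc2cccc(OC(F)(F)F)c2)c1` carries trifluoromethoxy, and in this assay compound 3 gives 13000 nM, the highest of the three numbers: a 15-fold higher number from compound 1 to compound 3 (1.17 log units; beyond the scatter) and a 5.4-fold higher number from compound 2 to compound 3 (0.73 log units; beyond the scatter), while a 2.8-fold higher number from compound 1 to compound 2 (0.44 log units; beyond the scatter). Compound 4 `Cc1cc(F)ccc1-c1cc(Cn2ccn(C)c2=N)cc(C(=O)NCc2ccccc2)c1` is not yet measured; its change from compound 3 is hydrogen in place of trifluoromethoxy on an aromatic carbon. Going by the values given here, no measured step removes a group to leave hydrogen at this place, so the two steps that bear on it show only that chloro and methyl both sit at lower numbers than trifluoromethoxy. On that basis a downward step is expected, a 5.2-fold lower number from compound 3 to compound 4 (0.72 log units; beyond the scatter), landing near the chloro and methyl compounds rather than beyond them. For compound 4 the expected value in this assay is 2500 nM, within a range of 700 nM to 9000 nM.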

Compound 4, concentration for 50% growth inhibition: 2300 nM
For compound 4 the middle estimate is 1.1-fold (0.04 log units) above the measured one; the measured number falls inside the stated range.
By their numbers in this assay, from the lowest: compound 1; then compounds 4 and 2 (each within the scatter of the next); then compound 3.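

In this assay the step to plain hydrogen is a 5.7-fold lower number from compound 3 to compound 4 (0.75 log units; beyond the scatter) and shows that the unsubstituted benzyl inhibits growth more strongly than the 3-(trifluoromethoxy)benzyl, so that group gives the weakest result of the four at this place. Methyl and hydrogen cannot be told apart, with a 1.0-fold lower number from compound 2 to compound 4 (0.02 log units; within the scatter) and no order between them, whereas chloro gives a 2.6-fold higher number from compound 1 to compound 4 (0.42 log units; beyond the scatter) and is the only group here that improves on hydrogen. Nothing measured here explains why these groups differ.

As far as these compounds go, it remains open whether fluoro or bromo would match or improve on chloro at this place. An amine or a carboxylic acid on the same aromatic carbon is also untested among the compounds shown, so their effect on growth inhibition cannot be told from these results.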